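The source may hold more compounds than are shown below. What is called first, only, known or untested is meant among the compounds shown, and "the series" means these compounds.

Measured so far in a functional assay on MCF7 cells (Homo sapiens) for antiproliferative activity, read by MTT assay, with a stated time of 48 h; on this read-out higher numbers stand for weaker inhibition and lower numbers for stronger inhibition:
- compound 1 `O=[N+]([O-])c1cccc(-c2nn(-c3ccccc3)cc2C(Nc2nc3ccccc3s2)c2c(O)ccc3ccccc23)c1`: 43900 nM
- compound 2 `COc1cccc(-c2nn(-c3ccccc3)cc2C(Nc2nc3ccccc3s2)c2c(O)ccc3ccccc23)c1`: 16900 nM
- compound 3 `COc1ccc(-c2nn(-c3ccccc3)cc2C(Nc2nc3ccccc3s2)c2c(O)ccc3ccccc23)cc1`: 17500 nM

Compound 3, at 17500 nM, cannot be separated from the other methoxy analogue: a 1.0-fold higher number from compound 2 to compound 3 (0.02 log units; within the scatter). The nitro analogue stands apart, with a 2.5-fold lower number from compound 1 to compound 3 (0.40 log units; beyond the scatter).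

Next is compound 4 `Oc1ccc2ccccc2c1C(Nc1nc2ccccc2s1)c1cn(-c2ccccc2)nc1-c1ccc(I)cc1`, which has iodo in place of methoxy on an aromatic carbon, para to a large group (iodo in place of methoxy on an aromatic carbon). Going by the values given here, no measured step exchanges methoxy for iodo, so the evidence is indirect. The nearest steps are the modest replacements of the nitro-bearing aryl group, a 2.6-fold lower number from compound 1 to compound 2 (0.41 log units; beyond the scatter) and a 2.5-fold lower number from compound 1 to compound 3 (0.40 log units; beyond the scatter). Together with the step between the two methoxy analogues, these suggest that this aryl group moves this assay only modestly across the three compounds. A small change is therefore expected, with no firm direction and perhaps a slight drift towards the nitro value.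

The expected change is a 1.1-fold higher number from compound 3 to compound 4 (0.06 log units; within the scatter), which is no step beyond the scatter. For compound 4 the estimated value is 20000 nM, with an expected range of 9000 nM to 45000 nM.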

Compound 4, half-maximal inhibitory concentration: 18900 nM
Estimate against measurement, compound 4: 1.1-fold (0.02 log units) above; the measured number falls inside the stated range.
By their numbers in this assay, from the lowest: compounds 2, 3 and 4 (each within the scatter of the next); then compound 1.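

Iodo on an aromatic carbon, para to a large group, cannot be separated from methoxy at that place in this assay (a 1.1-fold higher number from compound 3 to compound 4 (0.03 log units; within the scatter)). The 4-iodophenyl compound also stands level with the 3-methoxyphenyl analogue (a 1.1-fold higher number from compound 2 to compound 4 (0.05 log units; within the scatter)) and remains apart from the 3-nitrophenyl analogue (a 2.3-fold lower number from compound 1 to compound 4 (0.37 log units; beyond the scatter)), so compound 1 is the only one of the four set apart. No measurement at hand bears on why these groups behave this way.

Open, as far as these compounds go, is whether an amine or a carboxylic acid on this aryl group would leave the number at the level of compound 2, compound 3 and compound 4. Also open, from the compounds shown here alone, is whether the separation of compound 1 belongs to the nitro group itself or to its place on the ring.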